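Working notes: adding amino to compound 1

A few compounds are considered here, and "the series" means these few. Any claim that something is new, unique, unknown or untested is made for them only; others in the source may bear on it.

Measured in a functional assay on HepG2 cells (Homo sapiens) for cytotoxicity, read by sulforhodamine B assay, with a stated time of 48 h; a higher number here means a weaker inhibitor, a lower number a stronger inhibitor:
- compound 1 `CCn1cc(-c2nc3ccccc3[nH]2)c(=O)c2cc(F)c(N3CCNCC3)nc21`: 9100 nM
- compound 2 `CCn1cc(-c2nc3ccc([N+](=O)[O-])cc3[nH]2)c(=O)c2cc(F)c(N3CCNC(C)C3)c(F)c21`: 4200 nM
- compound 3 `CCn1cc(-c2nc3ccc([N+](=O)[O-])cc3o2)c(=O)c2cc(F)c(N3CCNC(C)C3)c(F)c21`: 4500 nM

Compound 1, at 9100 nM, has the highest number of the three, and its gap to each of the other two lies just beyond the usual scatter. The next compound is compound 4 `CCn1cc(-c2nc3ccc(N)cc3[nH]2)c(=O)c2cc(F)c(N3CCNCC3)nc21`, which has amino in place of hydrogen on an aromatic carbon of compound 1: amino in place of hydrogen on an aromatic carbon.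

Within the data shown here, no pair of measured compounds differs in one place only, so the effect of this change has not been measured directly. Compound 2 at 4200 nM and compound 3 at 4500 nM both stand lower than compound 1, but each differs from it in more than one place and gives only weak guidance. In this assay, a small move to a lower number is expected, with no step beyond the scatter. The expected step is a 1.4-fold lower number from compound 1 to compound 4 (0.15 log units; within the scatter). For compound 4, the estimated value is 6500 nM, with an expected range of 2500 nM to 16000 nM.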

Compound 4, half-maximal inhibitory concentration: > 10000 nM
Compound 4 ended at the assay's limit (the forecaster's own chance of this, stated with the estimate: 10%); middle value at least 1.5-fold (0.18 log units) from the limit.
By their numbers in this assay, from the lowest: compounds 2 and 3 (each within the scatter of the next); then compound 1. At a limit, above all of these: compound 4.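

In this assay compound 4 gives > 10000 nM, which is a limit of the assay and not a number. Among these compounds, this provides the first one-place reading for this aromatic carbon, meta to a fused ring and para to a fused ring: amino in place of hydrogen gives an at least 1.0-fold higher number from compound 1 to compound 4 (0.04 log units; that floor lies within the scatter), so the change brings no move to a lower number, contrary to what the earlier compounds loosely suggested. The reading fixes only a floor, and the full size of the step remains unknown: the limit of > 10000 nM in this assay, at which 1 of the 4 values shown sits.

As far as these compounds go, it remains open whether a methoxy group or an acetamide on this aromatic carbon would leave the number near that of compound 1 or also reach the limit. From the compounds shown here alone, it is also open whether amino has the same effect on the core of compound 2.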